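From benzoyl to (trifluoromethyl)carbonyl on a shared core

A few compounds are considered here, and "the series" means these few. Any claim that something is new, unique, unknown or untested is made for them only; others in the source may bear on it.

Of the compounds shown here, three sharing one core have been tested in a functional assay on MCF7 cells (Homo sapiens) for antiproliferative activity; on this read-out higher numbers stand for weaker inhibition and lower numbers for stronger inhibition. Compound 1 `CC(=O)N(C(C)=O)c1ccc(-c2nc3ccccc3s2)cc1` gives > 100 nM, which is a limit and not a number. Compound 2 `O=C(Nc1ccc(-c2nc3ccccc3s2)cc1)C(Cl)Cl` gives > 100 nM, also a limit. Compound 3 `O=C(Nc1ccc(-c2nc3ccccc3s2)cc1)c1ccccc1` gives > 1000 nM, again a limit. The record therefore holds only the limit of > 100 nM in this assay, at which 2 of the 3 values shown sit, and (the limit of > 1000 nM in this assay, at which 1 of the 3 values shown sits).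

Compound 4 `O=C(Nc1ccc(-c2nc3ccccc3s2)cc1)C(F)(F)F` is still unmeasured. It has trifluoromethyl in place of phenyl on a carbonyl carbon.

For the measured compounds named here, two measured steps bear on this change. Going by the values given here, the first is a step that the two limits leave unreadable from compound 1 to compound 2. The second and closer one, a step that the two limits leave unreadable from compound 2 to compound 3, changes the same carbonyl substituent. Neither has a size that can be read, so neither gives a firm direction for the new step. Weak inhibition is the only expectation these results support. The expected step is a step that the limit leaves unreadable from compound 3 to compound 4, an estimate with wide uncertainty. For compound 4 the estimated value is 1500 nM, with an expected range from 200 nM to 10000 nM.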

Compound 4, half-maximal inhibitory concentration: > 10 nM
Compound 4: no number, only a limit; the forecaster's own chance of this, stated with the estimate: 65%; the middle value lies beyond the limit too.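

Compound 4 gives > 10 nM, which is a limit and not a number. For the compounds shown here, compound 1, compound 2 and compound 3 also carry only limits, so no step among the four can be read. The compounds shown leave open the actual potency of all four and whether changing the carbonyl substituent alters it at all.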